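A few compounds are considered here, and "the series" means these few. Any claim that something is new, unique, unknown or untested is made for them only; others in the source may bear on it.

Measured in a functional assay on NCI-H1299 cells (Homo sapiens), read by flow cytometry; on this read-out higher numbers stand for an effect only at larger amounts of compound and lower numbers for an effect already at smaller amounts:
- compound 1 `N#Cc1ncc2nc1OCC/C=C\COc1ccc(O)cc1NC(=O)N2`: > 10000 nM (a limit)
- compound 2 `N#Cc1ncc2nc1OCC/C=C\COc1ccc(CCCOC3CCCCO3)cc1NC(=O)N2`: > 10000 nM (a limit)

In this assay, compound 2 gives > 10000 nM, which is a limit and not a number. The next compound, compound 3 `N#Cc1ncc2nc1OCC/C=C\COc1ccc(CCO)cc1NC(=O)N2`, differs from it as follows: hydroxy in place of ((oxan-2-yl)oxy)methyl on a saturated chain carbon, two bonds along the chain from an aromatic carbon. In words, this is hydroxy in place of ((oxan-2-yl)oxy)methyl on a saturated chain carbon, two bonds along the chain from an aromatic carbon. Within the data shown here, the only measured step that bears on this is a step that the two limits leave unreadable from compound 1 to compound 2, so it offers no size to carry over. All the data show is the limit of > 10000 nM in this assay, at which 2 of the 2 values shown sit. Only a modest move toward lower numbers is therefore expected, and compound 3 may well stay at the limit. The expected change is an at least 1.6-fold lower number from compound 2 to compound 3 (0.22 log units; that floor lies within the scatter). For compound 3 the estimated value is 6000 nM, within an expected range of 1500 nM to 10000 nM.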

Compound 3, half-maximal effective concentration: > 10000 nM
Compound 3 was reported as a limit (the forecaster's own chance of this, stated with the estimate: 55%); at least 1.6-fold (0.22 log units) between middle value and limit.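

Among these compounds, no step among compound 1, compound 2 and compound 3 can be read, because each result in this assay is only a limit: the limit of > 10000 nM in this assay, at which 3 of the 3 values shown sit. On these data alone, what the changes in the side chain do to the effect, in size or direction, stays open.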